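The source may report more compounds than this note shows. Statements on the series, on what has been measured and on what is new or still open speak of the compounds shown alone.

For the measured compounds named here, in a functional assay on MIA PaCa-2 cells (Homo sapiens) for cytotoxicity, read by MTT assay, with a stated time of 72 h (a lower number here means a stronger inhibitor, a higher number a weaker inhibitor), compound 2 (`COC1=CC(=O)c2c(COc3ccccc3)c(C)n(C)c2C1=O`) gives 409 nM and sits within the scatter of compound 1 (`COC1=CC(=O)c2c(COc3ccc([N+](=O)[O-])cc3)c(C)n(C)c2C1=O`), which gives 355 nM as the only other measured value. Compound 3 (`COC1=CC(=O)c2c(COc3cccc([N+](=O)[O-])c3)c(C)n(C)c2C1=O`) has nitro in place of hydrogen on an aromatic carbon, meta to a large group (nitro in place of hydrogen on an aromatic carbon). Going by the values given here, only one measured step bears on this, showing a 1.2-fold higher number from compound 1 to compound 2 (0.06 log units; within the scatter) for the same two groups on a different carbon of that ring. No step beyond the scatter is therefore expected in this assay for this change. The estimate amounts to an expected 1.1-fold lower number from compound 2 to compound 3 (0.03 log units; within the scatter) on this read-out. For compound 3 the estimated value is 380 nM with an expected range from 180 nM to 800 nM in this measurement.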

Compound 3, half-maximal inhibitory concentration: 257 nM
The estimate for compound 3 lay 1.5-fold (0.17 log units) above the measured number, within the range that was stated.
By their numbers in this assay, from the lowest: compounds 3, 1 and 2 (each within the scatter of the next).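

In this assay, nitro at this carbon, meta to a large group, gives a 1.6-fold lower number from compound 2 to compound 3 (0.20 log units; within the scatter). The earlier compounds shown here showed this only for nitro on a different carbon of the ring, so compound 3 adds a second place on that ring where the change stays within the scatter. No measurement shown here accounts for this result.

The compounds shown leave open whether an amine or a carboxylic acid on this same carbon would move the number beyond the scatter, as nitro does not.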